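The source may report more compounds than this note shows. Statements on the series, on what has been measured and on what is new or still open speak of the compounds shown alone.

Working notes on the series. In a functional assay on DU-145 cells (Homo sapiens) for inhibition, read by trypan blue exclusion, with a stated time of 96 h (on this read-out lower numbers stand for stronger inhibition of growth and higher numbers for weaker inhibition of growth), compound 1 (`Cc1ccc(CS/C(=C/c2cc(C)ccc2C)C(=O)c2ccc(Cl)cc2)cc1`) gives 10000 nM, and compound 2 (`CSc1ccc(/C=C(/SCc2ccc(C)cc2)C(=O)c2ccc(Cl)cc2)cc1`) gives 25000 nM. Compound 2 therefore holds the higher of the two numbers, which means the weaker inhibition of growth. Compound 3 (`Cc1ccc(CS/C(=C/c2ccc(O)c(O)c2O)C(=O)c2ccc(Cl)cc2)cc1`) has not yet been measured. It shares the core of compound 2 and differs at one place: 2,3,4-trihydroxyphenyl in place of 4-(methylsulfanyl)phenyl on a double-bonded chain carbon bound to a double-bonded chain carbon. The change is 2,3,4-trihydroxyphenyl in place of 4-(methylsulfanyl)phenyl on a double-bonded chain carbon bound to a double-bonded chain carbon.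

Going by the values given here, only one measured step bears on this place: a 2.5-fold higher number from compound 1 to compound 2 (0.40 log units; beyond the scatter), a modest step beyond the scatter. Among the compounds with values here, that step involves a different entering group, and no measured compound carries 2,3,4-trihydroxyphenyl, so the direction remains poorly fixed. A modest step of similar size is expected in this assay. The slight lean toward a lower number rests only on compound 2 standing at 25000 nM, the top of the two measured numbers. The expected change is a 2.1-fold lower number from compound 2 to compound 3 (0.32 log units; beyond the scatter). For compound 3 the estimated value is 12000 nM, with an expected range from 3000 nM to 50000 nM.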

Compound 3, concentration for 50% growth inhibition: 50000 nM
Compound 3: the middle estimate sits 4.2-fold (0.62 log units) below what was measured, and the stated range covers the measured number.
By their numbers in this assay, from the lowest: compound 1; then compounds 2 and 3 (each within the scatter of the next).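

In this assay, 2,3,4-trihydroxyphenyl in place of 4-(methylsulfanyl)phenyl gives a 2.0-fold higher number from compound 2 to compound 3 (0.30 log units; within the scatter), so on this double-bonded chain carbon the two groups cannot be told apart, even though the entering group has 3 hydrogen-bond donors and the leaving group has 0. Set against 2,5-dimethylphenyl, the same entering group gives a 5.0-fold higher number from compound 1 to compound 3 (0.70 log units; beyond the scatter), a step that is clearly readable and larger than the one from 2,5-dimethylphenyl to 4-(methylsulfanyl)phenyl seen earlier. Across the three compounds, then, the place tolerates quite different aromatic groups with only modest movement, and both replacements of 2,5-dimethylphenyl give higher numbers, with compound 1 remaining the one with the lowest number at 10000 nM.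

Still open, on these data alone, is whether a group of another kind at this place, such as an amine, a carboxylic acid or a longer chain ending in a hydroxy group, would move the number outside this narrow band, and whether a ring with a single hydroxy group would behave like the trihydroxy one. Nothing in hand offers a measured explanation for any of these numbers.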